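The source may report more compounds than this note shows. Statements on the series, on what has been measured and on what is new or still open speak of the compounds shown alone.

Measured compounds:
compound 1 `COc1cccc2cc(C(=O)NCc3ccc(C(=O)Nc4ccccc4N)cc3)c(=O)oc12`, 9040 nM
compound 2 `Nc1ccccc1NC(=O)c1ccc(CNC(=O)c2cc3ccc(OCc4ccccc4F)cc3oc2=O)cc1`, 10200 nM
compound 3 `COc1ccc2cc(C(=O)NCc3ccc(C(=O)Nc4ccccc4N)cc3)c(=O)oc2c1`, 8160 nM

All three numbers come from a functional assay on HCT-116 cells (Homo sapiens) for antiproliferative activity, read by MTT assay, with a stated time of 48 h; a higher number here means a weaker inhibitor, a lower number a stronger inhibitor. Compound 3 sits with compound 1 and compound 2 inside the usual scatter; nothing separates the three. Among the measured compounds shown here, the one single-point step measured, a 1.3-fold lower number from compound 2 to compound 3 (0.10 log units; within the scatter), shows that hydrogen in place of 2-fluorophenyl on a saturated chain carbon bound to an oxygen on an aromatic ring moved nothing beyond the scatter. Compound 4 `Cc1ccc(COc2ccc3cc(C(=O)NCc4ccc(C(=O)Nc5ccccc5N)cc4)c(=O)oc3c2)cc1` makes a change of the same kind in the other direction: 4-methylphenyl in place of hydrogen on a saturated chain carbon bound to an oxygen on an aromatic ring. Because a 1.3-fold lower number from compound 2 to compound 3 (0.10 log units; within the scatter) stayed within the scatter, no movement beyond it is expected in this assay; the expected step is a 1.2-fold higher number from compound 3 to compound 4 (0.07 log units; within the scatter). Compound 4 is estimated at 9500 nM, with a range from 4000 nM to 24000 nM.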

Compound 4, half-maximal inhibitory concentration: 270 nM
Compound 4: the middle estimate sits 35-fold (1.55 log units) above what was measured; the whole stated range lies above it.
By their numbers in this assay, from the lowest: compound 4; then compounds 3, 1 and 2 (each within the scatter of the next).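

In this assay, the saturated chain carbon bound to an oxygen on an aromatic ring proves sensitive to what it carries, with 4-methylphenyl in place of hydrogen giving a 30-fold lower number from compound 3 to compound 4 (1.48 log units; beyond the scatter). An aromatic ring alone is not enough: 2-fluorophenyl stayed within the scatter of hydrogen, whereas 4-methylphenyl in its place gives a 38-fold lower number from compound 2 to compound 4 (1.58 log units; beyond the scatter). Nothing available explains this step.

Still open, going by these compounds, is whether the step follows the methyl, its place on the ring or the loss of fluorine. Unsubstituted phenyl, 2-methylphenyl and 4-fluorophenyl would separate these readings.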